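From a Hydroxyethylamino Group to a Methylsulfanyl Group

The source may report more compounds than this note shows. Statements on the series, on what has been measured and on what is new or still open speak of the compounds shown alone.

Measured so far:
Compound 1 `CCCCCCNc1[nH]ccc2ncnc1-2`: 100%
Compound 2 `OCCNc1[nH]ccc2ncnc1-2`: < 5%
Compound 3 `c1ccc(Nc2[nH]ccc3ncnc2-3)cc1`: 26%

In a functional assay on EL4 cells (Mus musculus) for inhibition, tested at 100 uM (on this read-out higher numbers stand for more inhibition at the one concentration tested (going by the name of the read-out) and lower numbers for less inhibition), compound 1 gives 100%. For compound 2 only a limit is known, < 5%, which is the limit of < 5% in this assay, at which 1 of the 3 values shown sits. Compound 3 gives 26%. Compound 2 therefore stands at the very bottom of the numbers shown. Within the data shown here, the only measured step, a number at least 95 percentage points lower from compound 1 to compound 2 (beyond the scatter), shows how far a small change at this position can move the read-out. Compound 4 `CSc1[nH]ccc2ncnc1-2` has not yet been tested; it differs from compound 2 by methylsulfanyl in place of (2-hydroxyethyl)amino on an aromatic carbon. Among the measured compounds shown here, that step points in the opposite direction to the one measured, but no measured pair tells how large it will be. Compound 4 is expected to give 15%, within 0% to 45%, an estimated rise of a number at least 10 percentage points higher from compound 2 to compound 4 (that floor lies within the scatter).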

Compound 4, a percentage reported as inhibition, at one concentration (the size of the read-out at that concentration, not a potency): < 5%
Compound 4: no number, only a limit; the forecaster's own chance of this, stated with the estimate: 35%; middle value at least 10 percentage points away from the limit.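

Among these compounds, compound 2 and compound 4 each give only a limit, not a number, so no step between them can be read: the limit of < 5% in this assay, at which 2 of the 4 values shown sit. On these data alone, how far methylsulfanyl and (2-hydroxyethyl)amino truly differ on the shared core stays open.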